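Sulfonyl aryl swap on the unsubstituted indazole nitrogen analogue

The compounds below may be only part of what the source reports. "The series", "measured", "known", "first", "only" and "open" are said of these compounds alone.

Compound 2 `CN1CCN(c2ccc3[nH]nc(S(=O)(=O)c4ccc(F)cc4)c3c2)CC1` stands highest of the three numbers in a functional assay on HeLa cells for antagonist activity at 5-hydroxytryptamine receptor 6 (Homo sapiens); a higher number here means a weaker inhibitor, a lower number a stronger inhibitor: compound 2 gives 467 nM, whereas compound 1 `CCn1nc(S(=O)(=O)c2cccc3ccccc23)c2cc(N3CCN(C)CC3)ccc21` gives 1.7 nM and compound 3 `CN1CCN(c2ccc3c(c2)c(S(=O)(=O)c2cccc4ccccc24)nn3Cc2ccccc2)CC1` gives 2 nM. For the measured compounds named here, the one single-point step, a 1.2-fold higher number from compound 1 to compound 3 (0.07 log units; within the scatter), concerns the substituent on the ring nitrogen and says nothing about the group on the sulfonyl sulfur. Compounds 1 and 3 differ from compound 2 in more than one place, so their much lower numbers cannot be assigned to any one change.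

Compound 4 `CN1CCN(c2ccc3[nH]nc(S(=O)(=O)c4c(Cl)cccc4Cl)c3c2)CC1` differs from compound 2 as follows: 2,6-dichlorophenyl in place of 4-fluorophenyl on a sulfonyl sulfur. Going by the values given here, no measured step bears on this change, and nothing shows what a second halogen or a change of halogen on this ring does. The working expectation is therefore only a loose one: a step of a 3.1-fold lower number from compound 2 to compound 4 (0.49 log units; beyond the scatter) is estimated, with wide uncertainty in either direction. For compound 4 the estimate in this assay is 150 nM, between 25 nM and 900 nM.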

Compound 4, half-maximal inhibitory concentration: 40 nM
The estimate for compound 4 lay 3.8-fold (0.57 log units) above the measured number; measured number inside the range.
By their numbers in this assay, from the lowest: compounds 1 and 3 (each within the scatter of the next); then compound 4; then compound 2.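

The group on the sulfonyl sulfur now has a measured effect in this assay: the change to 2,6-dichlorophenyl gives a 12-fold lower number from compound 2 to compound 4 (1.07 log units; beyond the scatter), the first step read at this position. For the compounds shown here, the only earlier step, a 1.2-fold higher number from compound 1 to compound 3 (0.07 log units; within the scatter), concerned the substituent on the ring nitrogen, so this is the first sign that the number responds to a single change on this core. No measurement available here accounts for the size of the step.

The change replaces one fluorine with two chlorines, so halogen identity, halogen count and ring placement cannot be separated from this pair. Going by these compounds, whether plain phenyl, or a phenyl carrying a single chlorine, would sit nearer compound 2 or compound 4 remains open.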